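Methoxy in place of fluoro: an estimate for compound 4

A few compounds are considered here, and "the series" means these few. Any claim that something is new, unique, unknown or untested is made for them only; others in the source may bear on it.

Compound 1 `CCN1CCN(c2cc(C)c3cc(NC(=O)c4ccc(F)cc4)ccc3n2)CC1` gives 4030 nM in a functional assay on MCF7 cells (Homo sapiens) for antiproliferative activity, read by MTT assay, with a stated time of 72 h (a higher number here means a weaker inhibitor, a lower number a stronger inhibitor), the lowest of the three numbers measured on this core. Compound 2 `CCN1CCN(c2cc(C)c3cc(NC(=O)c4ccccc4C)ccc3n2)CC1` gives 10900 nM and compound 3 `CCN1CCN(c2cc(C)c3cc(NC(=O)c4ccccc4Br)ccc3n2)CC1` gives 27500 nM. Both steps away from compound 1 raise the number: a 2.7-fold higher number from compound 1 to compound 2 (0.43 log units; beyond the scatter) and a 6.8-fold higher number from compound 1 to compound 3 (0.83 log units; beyond the scatter), and between the two other compounds a 2.5-fold higher number from compound 2 to compound 3 (0.40 log units; beyond the scatter).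

Compound 4 `CCN1CCN(c2cc(C)c3cc(NC(=O)c4ccc(OC)cc4)ccc3n2)CC1` differs from compound 1 by methoxy in place of fluoro on an aromatic carbon. Going by the values given here, none of the measured steps exchanges one group for another at this same place; the two steps from compound 1 both move the substituent elsewhere on the ring and change its identity at once, and each gave a modest rise. They show that compound 1 sits at the favourable end of this small set, and that changes to its 4-fluorophenyl have so far only weakened the inhibitor, but they do not test a methoxy at all. On that basis compound 4 is expected to stay near compound 1 or to drift somewhat higher, with the step of a 1.5-fold higher number from compound 1 to compound 4 (0.17 log units; within the scatter) expected to be small. Compound 4 is therefore estimated at 6000 nM, with a likely range from 2500 nM to 15000 nM.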

Compound 4, half-maximal inhibitory concentration: 7690 nM
Estimate against measurement, compound 4: 1.3-fold (0.11 log units) below, within the range that was stated.
By their numbers in this assay, from the lowest: compounds 1, 4 and 2 (each within the scatter of the next, the first and the last beyond it); then compound 3.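

In this assay, going by these compounds alone, the exchange of 4-fluorophenyl for 4-methoxyphenyl is the first in this set that swaps one group for another at the same place, and the step, a 1.9-fold higher number from compound 1 to compound 4 (0.28 log units; within the scatter), shows that replacing fluoro with methoxy leaves the number within the scatter. The earlier steps shown here had only raised the number on leaving compound 1, so this pair adds a change to its 4-fluorophenyl that cannot be told apart from no change, although it rests on a single pair. The other two comparisons place compound 4 within the set: the step of a 1.4-fold lower number from compound 2 to compound 4 (0.15 log units; within the scatter) does not separate it from the 2-methylphenyl amide, whereas the step of a 3.6-fold lower number from compound 3 to compound 4 (0.55 log units; beyond the scatter) does separate it from the 2-bromophenyl amide.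

Nothing shown here gives a reason for these numbers. Going by these compounds, it remains open whether an amine, a carboxylic acid or a longer chain such as ethoxy at this same place would also stay close to compound 1, and whether methoxy would give a similar step on a different core.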